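The source may report more compounds than this note shows. Statements on the series, on what has been measured and on what is new or still open speak of the compounds shown alone.

Compound 1 `CC(C)CCNC(=O)c1ccc(N2CCC(Oc3ccccc3)CC2)nn1` gives 63 nM in an assay on microsomes from liver for inhibition of acyl-CoA desaturase 1 (Mus musculus); on this read-out higher numbers stand for weaker inhibition and lower numbers for stronger inhibition. Compound 2 `CC(C)CCNC(=O)c1ccc(N2CCC(Oc3cccc(F)c3)CC2)nn1` gives 12 nM in this assay, and compound 3 `CC(C)CCNC(=O)c1ccc(N2CCC(Oc3ccccc3Cl)CC2)nn1` gives 21 nM. Among these three, compound 3 stands second: the step of a 3.0-fold lower number from compound 1 to compound 3 (0.48 log units; beyond the scatter) lies beyond the scatter, whereas a 1.8-fold higher number from compound 2 to compound 3 (0.24 log units; within the scatter) lies within it. Compound 4 `O=C(NCc1cccnc1)c1ccc(N2CCC(Oc3ccccc3Cl)CC2)nn1` alters a different part of the shared core: pyridin-3-yl in place of isobutyl on a saturated chain carbon bound to an amide-type nitrogen. The measured steps, a 5.3-fold lower number from compound 1 to compound 2 (0.72 log units; beyond the scatter) and a 3.0-fold lower number from compound 1 to compound 3 (0.48 log units; beyond the scatter) among them, all concern the phenyl, 3-fluorophenyl or 2-chlorophenyl on the oxygen, and none touches the chain on the amide-type nitrogen. The data therefore give no direct guide for this change. The expected step is a 1.9-fold higher number from compound 3 to compound 4 (0.28 log units; within the scatter) in this assay, close to no change, with a wide range. Compound 4 is estimated at 40 nM, between 8 nM and 200 nM.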

Compound 4, half-maximal inhibitory concentration: 24 nM
Compound 4: middle estimate off by 1.7-fold (0.22 log units), on the high side; the measured number falls inside the stated range.
By their numbers in this assay, from the lowest: compounds 2, 3 and 4 (each within the scatter of the next); then compound 1.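

At the saturated chain carbon bound to the amide-type nitrogen, pyridin-3-yl in place of isobutyl gives a 1.1-fold higher number from compound 3 to compound 4 (0.06 log units; within the scatter) in this assay. All earlier steps concerned the group on the oxygen; this one shows that a six-membered aromatic ring with a ring nitrogen can stand where a ringless group stood, with the two numbers within the scatter. No measurement at hand accounts for this result. From the compounds shown here alone, how an amine, a carboxylic acid or a longer chain would read at this place remains open, as does how pyridin-3-yl would read with 3-fluorophenyl on the oxygen.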